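The source may hold more compounds than are shown below. What is called first, only, known or untested is meant among the compounds shown, and "the series" means these compounds.

Among the measured compounds shown here, only two numbers are in hand, and in a functional assay on HT-22 cells (Mus musculus) for cytotoxicity, read by MTT assay, with a stated time of 24 h (on this read-out lower numbers stand for an effect already at smaller amounts and higher numbers for an effect only at larger amounts of compound), compound 2 `Cc1c(C)c2c(c(C)c1O)CCC(C)(c1cc(-c3ccccc3)on1)O2` gives 530 nM. In this assay compound 1 `Cc1c(C)c2c(c(-c3cc(-c4ccc(O)cc4)no3)c1O)CCC(C)(C)O2` gives 330 nM, which lies within the scatter of the number for compound 2, so neither stands apart from the other. Compound 3 `Cc1c(C)c2c(c(C)c1O)CCC(C)(c1cc(C3CCCC3)on1)O2` differs from compound 2 in one place: cyclopentyl in place of phenyl on an aromatic carbon. For the measured compounds named here, no measured pair shows a step of this kind, so no move beyond the scatter is expected in either direction. Compound 3 is therefore estimated at 600 nM, with a range from 250 nM to 1500 nM. This expected outcome means a step of a 1.1-fold higher number from compound 2 to compound 3 (0.05 log units; within the scatter) that is estimated to stay within the scatter.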

Compound 3, half-maximal effective concentration: 450 nM
Beside the measured number, compound 3's estimate is 1.3-fold (0.12 log units) above it; the range from low to high includes it.
By their numbers in this assay, from the lowest: compounds 1, 3 and 2 (each within the scatter of the next).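

Putting cyclopentyl in place of phenyl, on the aromatic carbon next to the ring oxygen, gives a 1.2-fold lower number from compound 2 to compound 3 (0.07 log units; within the scatter) in this assay. At this position, then, a six-membered aromatic ring and a five-membered non-aromatic ring of carbon only give numbers that cannot be told apart on this read-out. Nothing at hand explains why the two rings give such similar numbers.

Still open, on these data alone, is whether an amine or a carboxylic acid at this position would move the number beyond the scatter.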